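This account rests on a few compounds, and the source may have more. Where it says the series, first, only, none or still open, it means among the compounds named here.

Measured so far:
compound 1 `C#CCN(C)Cc1cn(-c2cc(NC(=S)NCC)ncn2)cn1` — 1430 nM
compound 2 `C#CCN(Cc1cn(-c2cc(NC(=S)NCC)ncn2)cn1)C(C)=O` — > 50000 nM

In an assay on isolated protein for inhibition of Amine oxidase [flavin-containing] B (Homo sapiens), read by fluorescence and Amplex Red, with a stated time of 15 min (on this read-out lower numbers stand for stronger inhibition and higher numbers for weaker inhibition), compound 2 stands only at the assay limit, > 50000 nM; this is a limit, not a number (the limit of > 50000 nM in this assay, at which 1 of the 2 values shown sits). Compound 3 `C#CCN(CC#C)Cc1cn(-c2cc(NC(=S)NCC)ncn2)cn1` is unmeasured. Its change from compound 2: propargyl in place of acetyl on an amine nitrogen. Among the measured compounds shown here, the one measured step, an at least 34-fold higher number from compound 1 to compound 2 (1.54 log units; beyond the scatter), runs the opposite way, acetyl entering for methyl, and was large. Undoing the acetyl is therefore expected to bring the number back down sharply, an at least 25-fold lower number from compound 2 to compound 3 (1.39 log units; beyond the scatter). Compound 3 is estimated at 2000 nM, in the range 500 nM to 8000 nM.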

Compound 3, half-maximal inhibitory concentration: > 50000 nM
Compound 3: no number, only a limit; the forecaster's own chance of this, stated with the estimate: 10%; middle value at least 25-fold (1.39 log units) away from the limit.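

In this assay, the loss at this amine nitrogen does not depend on a carbonyl: ethynyl added to the methyl, giving the propargyl of compound 3, already produces an at least 34-fold higher number from compound 1 to compound 3 (1.54 log units; beyond the scatter). Methyl is thus the only group on this nitrogen among the compounds shown that gives a measurable number. The step from compound 2 to compound 3 cannot be read, as both values are limits: the limit of > 50000 nM in this assay, at which 2 of the 3 values shown sit.

On these data alone, how much size this nitrogen tolerates remains open. Ethyl or hydrogen in place of the methyl would show whether the activity falls gradually or abruptly beyond methyl.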